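Extending a methyl to butyl on a weak antiproliferative series

The compounds below may be only part of what the source reports. "The series", "measured", "known", "first", "only" and "open" are said of these compounds alone.

Compound 1 `NS(=O)(=O)NCC1CCN(c2cc(-c3ccccc3)ncn2)CC1`: in a functional assay on MCF7 cells (Homo sapiens) for antiproliferative activity, read by sulforhodamine B assay, with a stated time of 48 h (a lower number here means a stronger inhibitor of growth, a higher number a weaker inhibitor of growth), compound 1 gives 34300 nM.
Compound 2 `Cc1ccc(-c2cc(N3CCC(CNS(N)(=O)=O)CC3)ncn2)cc1`: in this assay compound 2 gives 30600 nM.

Both measured compounds sit at the weak end of this assay. Compound 2 has the lowest of the two numbers, but its nearest neighbour is compound 1, and the step of a 1.1-fold lower number from compound 1 to compound 2 (0.05 log units; within the scatter) is within the scatter, so the two compounds cannot be told apart on these numbers.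

Compound 3 `CCCCc1ccc(-c2cc(N3CCC(CNS(N)(=O)=O)CC3)ncn2)cc1` has not yet been measured. It differs from compound 2 by propyl in place of hydrogen on a saturated chain carbon bound to an aromatic carbon. Among the compounds with values here, the only measured step that bears on this change is a 1.1-fold lower number from compound 1 to compound 2 (0.05 log units; within the scatter), which shows that a methyl in place of hydrogen on the same aromatic carbon left this assay unchanged within the scatter. Within the data shown here, with one step as the sole guide, and that step flat, no change beyond the scatter is expected from the further extension to butyl, and a step of about a 1.2-fold lower number from compound 2 to compound 3 (0.09 log units; within the scatter) is estimated. For compound 3 a value of 25000 nM is therefore expected, with a range from 8000 nM to 80000 nM.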

Compound 3, concentration for 50% growth inhibition: 21800 nM
Compound 3: the middle estimate sits 1.1-fold (0.06 log units) above what was measured, within the range that was stated.
By their numbers in this assay, from the lowest: compounds 3, 2 and 1 (each within the scatter of the next).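

Carrying the methyl out to butyl, which adds propyl with its 3 heavy atoms on a saturated chain carbon bound to an aromatic carbon, gives a 1.4-fold lower number from compound 2 to compound 3 (0.15 log units; within the scatter) in this assay and so adds no change that can be told from the scatter. Within the data shown here, measured against hydrogen on the aromatic carbon, butyl gives a 1.6-fold lower number from compound 1 to compound 3 (0.20 log units; within the scatter) and is likewise not separated from it, so this position now reads flat across hydrogen, methyl and butyl, whereas the earlier compounds covered only hydrogen and methyl. No evidence is available to explain this flat reading.

Going by these compounds, whether an amine or a carboxylic acid on the same aromatic carbon, or a chain longer than butyl, would move the number beyond the scatter remains open. The compounds shown also leave open whether any change elsewhere on the shared core would bring the series out of the weak end of this assay.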